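Trimming the side chain of compound 2

The source may hold more compounds than are shown below. What is called first, only, known or untested is meant among the compounds shown, and "the series" means these compounds.

Compound 2 `CCC(C)C1NC(=O)N(C2CCCC2)C1=O` is known in a functional assay on HEp-2 cells (Homo sapiens) for inhibition (on this read-out lower numbers stand for stronger inhibition and higher numbers for weaker inhibition), only as a limit of the assay: compound 2 gives > 100000 nM. Compound 1 `CCC(C)C(NC(=O)NO)C(=O)NC1CCCCC1` is likewise only a limit, at > 100000 nM. Among the measured compounds shown here, compound 2 stands at the limit of > 100000 nM in this assay, at which 2 of the 2 values shown sit, with compound 1 beside it; nothing measured so far shows inhibition within the range of this assay. Compound 3 `CC(C)C1NC(=O)N(C2CCCC2)C1=O` differs from compound 2 by hydrogen in place of methyl on a saturated chain carbon, two bonds along the chain from a saturated ring carbon — hydrogen in place of methyl on a saturated chain carbon, two bonds along the chain from a saturated ring carbon. For the measured compounds named here, no measured step exists in this assay, and the estimated step of a number no higher from compound 2 to compound 3 (the limit leaves the size open) is expected to be none beyond the scatter, in no direction. Compound 3 is therefore expected near 100000 nM, most likely again only a limit, within 30000 nM to 300000 nM.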

Compound 3, half-maximal inhibitory concentration: 98000 nM
Compound 3: middle estimate off by 1.0-fold (0.01 log units), on the high side; the range from low to high includes it.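

Among the compounds shown here, compound 3 gives 98000 nM in this assay as the first number that is not a limit. Going by these compounds, the trim from sec-butyl to isopropyl reads as an at least 1.0-fold lower number from compound 2 to compound 3 (0.00 log units; that floor lies within the scatter) and, with compound 2 only a limit, the true size of the step stays open. The read-out remains crowded at its top end: the limit of > 100000 nM in this assay, at which 2 of the 3 values shown sit.

On these data alone, whether a longer chain, an amine or a carboxylic acid at this place would bring the number well down stays open. The compounds shown also leave open how much this side chain matters for inhibition at all.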